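Aryloxyphenyl pyrrolidine acids: from compound 2 to compound 4

The compounds below may be only part of what the source reports. "The series", "measured", "known", "first", "only" and "open" are said of these compounds alone.

compound 1 `Cc1ccccc1COc1ccc(N2CCC[C@H]2CC(=O)O)cn1` — in a functional assay on cells for agonist activity at Free fatty acid receptor 1 (Mus musculus), read by FLIPR and calcium flux, with a stated time of 100 s (a higher number here means that more compound is needed for the effect, a lower number that less compound is needed), compound 1 gives only a limit, > 33000 nM.
compound 2 `O=C(O)C[C@@H]1CCCN1c1ccc(Oc2ccc(Cl)cc2Cl)cc1` — compound 2 gives 3200 nM.
compound 3 `CN(C)c1cccc(Oc2ccc(N3CCC[C@H]3CC(=O)O)cc2)c1` — compound 3 gives only a limit, > 33000 nM.

For the measured compounds named here, compound 2 stands as the sole compound with a number in this assay; the other two are represented by the limit of > 33000 nM in this assay, at which 2 of the 3 values shown sit. Compound 4 `COc1ccc(Oc2ccc(N3CCC[C@H]3CC(=O)O)cc2)cc1` differs from compound 2 in one place: 4-methoxyphenyl in place of 2,4-dichlorophenyl on an oxygen on an aromatic ring. Going by the values given here, no step between measured compounds is available to rest on, so the size of the change is open. The expectation is that compound 4 loses ground against compound 2, with the step from compound 2 to compound 4 estimated as a 3.8-fold higher number from compound 2 to compound 4 (0.57 log units; beyond the scatter), a step expected to lie beyond the scatter. Compound 4 is therefore estimated at 12000 nM, within a range of 3500 nM to 40000 nM, with a fair chance that only a limit is reported.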

Compound 4, half-maximal effective concentration: > 33000 nM
Compound 4: a limit, no number (the forecaster's own chance of this, stated with the estimate: 35%); at least 2.7-fold (0.43 log units) between middle value and limit.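

For the compounds shown here, replacing 2,4-dichlorophenyl with 4-methoxyphenyl on the oxygen gives the first step that can be read at this position: an at least 10-fold higher number from compound 2 to compound 4 (1.01 log units; beyond the scatter). In this assay, from the compounds shown here alone, compound 4 gives only a limit, > 33000 nM, so the full size of the step stays unknown. Compound 2 remains the only compound with a number: the limit of > 33000 nM in this assay, at which 3 of the 4 values shown sit.

The compounds shown leave open whether the step follows from losing the chlorine atoms or from gaining the methoxy group. A single chlorophenyl or an unsubstituted phenyl on that oxygen would separate the two.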